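Methoxy Additions on a Shared Core: Three Measured, One Pending

The source may report more compounds than this note shows. Statements on the series, on what has been measured and on what is new or still open speak of the compounds shown alone.

Compound 1 `COC(=O)/C(=C\c1ccc(OC(=O)c2ccc(OC)cc2)cc1)Sc1ccnc2cc(Cl)ccc12` gives 9090 nM in a functional assay on HL-60 cells (Homo sapiens) for cytotoxicity, read by MTT assay, with a stated time of 24 h; a higher number here means a weaker inhibitor, a lower number a stronger inhibitor. Compound 2 `COC(=O)/C(=C\c1ccc(OC(=O)c2ccc(OC)cc2OC)cc1)Sc1ccnc2cc(Cl)ccc12` carries methoxy in place of hydrogen on an aromatic carbon and in this assay compound 2 gives 7640 nM, a step of a 1.2-fold lower number from compound 1 to compound 2 (0.08 log units; within the scatter). Compound 3 `COC(=O)/C(=C\c1ccc(OC(=O)c2cccc(OC)c2OC)cc1)Sc1ccnc2cc(Cl)ccc12` differs from compound 1 by 2,3-dimethoxyphenyl in place of 4-methoxyphenyl on a carbonyl carbon; in this assay compound 3 gives 13000 nM, with a 1.4-fold higher number from compound 1 to compound 3 (0.16 log units; within the scatter) and a 1.7-fold higher number from compound 2 to compound 3 (0.23 log units; within the scatter). Compound 4 `COC(=O)/C(=C\c1ccc(OC(=O)c2cc(OC)cc(OC)c2OC)cc1)Sc1ccnc2cc(Cl)ccc12` awaits measurement and differs from compound 3 by methoxy in place of hydrogen on an aromatic carbon. This is the same kind of change as that between compound 1 and compound 2, but the place differs: there the entering methoxy sat ortho to a large group and meta to a methoxy group, whereas here it sits meta to a large group, meta to a methoxy group and para to a methoxy group. Compound 4 is expected to move by only a 1.2-fold lower number from compound 3 to compound 4 (0.07 log units; within the scatter), an expectation resting on the earlier step because a 1.2-fold lower number from compound 1 to compound 2 (0.08 log units; within the scatter). Compound 4 is estimated at 11000 nM, between 5000 nM and 25000 nM.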

Compound 4, half-maximal inhibitory concentration: 10700 nM
The estimate for compound 4 lay 1.0-fold (0.01 log units) above the measured number, and the stated range covers the measured number.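

In this assay, the methoxy addition gave matching steps on the two cores: the same change on two cores in this assay, a 1.2-fold lower number (0.08 log units; within the scatter) from compound 1 to compound 2 and a 1.2-fold lower number (0.08 log units; within the scatter) from compound 3 to compound 4, 1.0-fold (0.01 log units) apart, within the scatter of two such steps. This shows that the change carried across this one pair of cores without a visible difference, but each step is itself within the scatter, so it shows no effect of the addition that could be carried to another core, and the entering methoxy sits at a different place in each pair. Compound 4 likewise stays within the scatter of all three other compounds, with a 1.2-fold lower number from compound 3 to compound 4 (0.08 log units; within the scatter), a 1.4-fold higher number from compound 2 to compound 4 (0.15 log units; within the scatter) and a 1.2-fold higher number from compound 1 to compound 4 (0.07 log units; within the scatter).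

The compounds shown leave open whether a hydroxyl, an amine or a carboxylic acid in place of methoxy on this ring would move the number beyond the scatter. They also leave open whether the methoxy addition would give matching steps on a core carrying a different group at the methyl ester.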